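Ethyl for bromo on the ring in compound 4

The source may report more compounds than this note shows. Statements on the series, on what has been measured and on what is new or still open speak of the compounds shown alone.

Compound 3 `C=CCOc1ccc(C(=O)Nc2cccc(Br)n2)cc1` gives 65500 nM in an in vitro assay on HEK-tsA201 cells for antagonist activity at Neuronal acetylcholine receptor; alpha3/beta4 (Homo sapiens), read by fluorescence and calcium flux (a higher number here means a weaker inhibitor, a lower number a stronger inhibitor), the highest of the three numbers measured; compound 1 `C=CCOc1ccc(C(=O)Nc2cccc(C)n2)cc1` gives 31700 nM and compound 2 `C=C(C)COc1ccc(C(=O)Nc2cccc(C)n2)cc1` gives 24700 nM in this assay. Compound 4 `C=CCOc1ccc(C(=O)Nc2cccc(CC)n2)cc1` differs from compound 3 by ethyl in place of bromo on an aromatic carbon. The step that bears on it is a 2.1-fold higher number from compound 1 to compound 3 (0.32 log units; beyond the scatter), which read backwards points to a lower number when bromo gives way to methyl. Whether ethyl behaves like methyl at this place is not measured; the methyl added on the chain gave a 1.3-fold lower number from compound 1 to compound 2 (0.11 log units; within the scatter), so a second carbon is not expected to matter much. A modest fall in the number is therefore expected, a 2.2-fold lower number from compound 3 to compound 4 (0.34 log units; beyond the scatter). Compound 4 is estimated at 30000 nM, in a range from 12000 nM to 75000 nM.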

Compound 4, half-maximal inhibitory concentration: 27400 nM
Beside the measured number, compound 4's estimate is 1.1-fold (0.04 log units) above it; the measured number falls inside the stated range.
By their numbers in this assay, from the lowest: compounds 2, 4 and 1 (each within the scatter of the next); then compound 3.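

At this place on the ring, next to the ring nitrogen, ethyl in place of bromo gives a 2.4-fold lower number from compound 3 to compound 4 (0.38 log units; beyond the scatter) in this assay and so matches the direction already seen with methyl. Ethyl and methyl at the same place give a 1.2-fold lower number from compound 1 to compound 4 (0.06 log units; within the scatter) in this comparison, so the extra carbon brings no readable difference. Nothing measured explains why bromo differs from ethyl here.

Open, going by these compounds, is whether a longer chain, an isopropyl group or an amine at this place would stay level with compound 1 and compound 4. Also open, on these data alone, is whether the methyl on the chain of compound 2 would act the same way alongside ethyl.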